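The source may report more compounds than this note shows. Statements on the series, on what has been measured and on what is new or still open speak of the compounds shown alone.

Within the three compounds measured, compound 2 `COC(=O)[C@@]1(C)CCC=C2[C@@H]1CC[C@@H](C)[C@]2(C)Cc1c(C)[nH]c2ccccc12` gives 15000 nM in a functional assay on A549 cells (Homo sapiens) for inhibition, read by sulforhodamine B assay, with a stated time of 48 h; on this read-out lower numbers stand for stronger inhibition of growth and higher numbers for weaker inhibition of growth. Compound 3 `COC(=O)[C@@]1(C)CCC=C2[C@@H]1CC[C@@H](C)[C@]2(C)Cc1c(C)[nH]c2ccc(F)cc12` gives 15000 nM, and no change at the digits printed from compound 2 to compound 3 (within the scatter), so these two stand together as the highest numbers of the three. Compound 1 `COC(=O)[C@@]1(C)CCC=C2[C@@H]1CC[C@@H](C)[C@]2(C)Cc1c[nH]c2ccccc12` gives 5000 nM; a 3.0-fold higher number from compound 1 to compound 2 (0.48 log units; beyond the scatter).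

Compound 4 `COC(=O)[C@@]1(C)CCC=C2[C@@H]1CC[C@@H](C)[C@]2(C)Cc1c(C)[nH]c2c(Br)cccc12` is reached from compound 2 by bromo in place of hydrogen on an aromatic carbon. Among the compounds with values here, no measured step puts a bromo anywhere on the shared core. Within the data shown here, the only step that bears on a substituent entering an aromatic carbon of the same six-membered ring is the fluoro one: no change at the digits printed from compound 2 to compound 3 (within the scatter). That step was flat, and nothing measured contradicts it, so a bromo on another aromatic carbon of that ring is read the same way. The methyl step, a 3.0-fold higher number from compound 1 to compound 2 (0.48 log units; beyond the scatter), concerns a different carbon and is not used here beyond noting that additions around this part of the core have so far not lowered the number.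

The step from compound 2 to compound 4 is therefore expected to be none beyond the scatter, that is no change at the digits printed from compound 2 to compound 4 (within the scatter) as an estimate. Compound 4 is expected to give about 15000 nM in this assay, with a range from 6000 nM to 40000 nM.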

Compound 4, concentration for 50% growth inhibition: 27000 nM
Compound 4: middle estimate off by 1.8-fold (0.26 log units), on the low side, and the stated range covers the measured number.
By their numbers in this assay, from the lowest: compound 1; then compounds 2, 3 and 4 (each within the scatter of the next).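

In this assay, bromo in place of hydrogen on this aromatic carbon, ortho to a fused ring, gives a 1.8-fold higher number from compound 2 to compound 4 (0.26 log units; within the scatter) and so stays within the scatter, which shows that this position accepts a single bromine atom with no readable shift in growth inhibition. The fluoro step on another aromatic carbon of the same six-membered ring, no change at the digits printed from compound 2 to compound 3 (within the scatter) in the same read-out, is also within the scatter, so two different halogens at two different carbons of this ring now leave the number unresolved from compound 2, although this holds only for these two substitutions. No accompanying measurement bears on this result, and the step remains an observation without an explanation.

Still open, going by these compounds, is whether a group of another kind on this aromatic carbon, such as an amine, a methoxy group or a carboxylic acid, would move the number beyond the scatter, in either direction. Also open is whether bromo would read the same on a core without the methyl that accounts for a 3.0-fold higher number from compound 1 to compound 2 (0.48 log units; beyond the scatter) in this series, the only step shown that lies beyond the scatter.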